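Swapping an Aryl Amine for a Dialkyl Amine

The compounds below may be only part of what the source reports. "The series", "measured", "known", "first", "only" and "open" are said of these compounds alone.

This study follows a small set of compounds sharing one fused core, tested in a functional assay on ECa-109 cells for inhibition, with ECa-109 cell line (Homo sapiens) as the target, read by sulforhodamine B assay; on this read-out lower numbers stand for stronger inhibition and higher numbers for weaker inhibition. Among the compounds with values here, compound 1, with the structure `O=C1C=C(Nc2ccc(I)cc2)C(=O)c2c1nc1n2[C@H]2OC[C@@H](O)[C@H]2OC1`, gives 2300 nM in this assay and is the only compound here with a definite number. Compound 2, with the structure `O=C1C(N2CCCCC2)=CC(=O)c2c1nc1n2[C@H]2OC[C@@H](O)[C@H]2OC1`, is reported only as > 8000 nM in this assay, which is a limit of the measurement rather than a number; this is the limit of > 8000 nM in this assay, at which 1 of the 2 values shown sits. Compound 3, with the structure `CCCN(CCC)C1=CC(=O)c2nc3n(c2C1=O)[C@H]1OC[C@@H](O)[C@H]1OC3`, has not yet been measured in this assay. It differs from compound 1 in one place: dipropylamino in place of (4-iodophenyl)amino on a double-bonded ring carbon. Within the data shown here, no measured pair of compounds maps this change directly, so the expectation rests on the two values shown. Compound 3 is expected to come out weaker than compound 1, with a step of a 2.6-fold higher number from compound 1 to compound 3 (0.42 log units; beyond the scatter) in this assay that lies beyond the usual scatter. The estimate for compound 3 is 6000 nM, with a likely range from 2000 nM to 20000 nM.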

Compound 3, half-maximal inhibitory concentration: > 16000 nM
Compound 3: no number, only a limit; the forecaster's own chance of this, stated with the estimate: 40%; middle value at least 2.6-fold (0.42 log units) away from the limit.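

Dipropylamino in place of (4-iodophenyl)amino on this double-bonded ring carbon produces an at least 6.9-fold higher number from compound 1 to compound 3 (0.84 log units; beyond the scatter) in this assay, so activity in these cells depends on what this carbon carries. The earlier pair of compounds could not make this point. Within the data shown here, no step linked them. From the compounds shown here alone, the true size of the step stays unknown, since compound 3 is reported only as a limit of the measurement: the limit of > 16000 nM in this assay, at which 1 of the 3 values shown sits. Compound 2 is also reported only as a limit, which leaves a definite number for just one of the three compounds: the limit of > 8000 nM in this assay, at which 1 of the 3 values shown sits.

This single change removes the aromatic ring, the iodine and the amine hydrogen together, so the data cannot tell which of these parts matters, or whether it is the loss of all three. A plain phenylamino group would keep the ring and the amine hydrogen without the iodine, and a propylamino group would keep the amine hydrogen without the ring, so either group at this carbon could begin to separate these parts.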